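A few compounds are considered here, and "the series" means these few. Any claim that something is new, unique, unknown or untested is made for them only; others in the source may bear on it.

Among the compounds with values here, in an assay on isolated protein for inhibition of Amine oxidase [flavin-containing] A (Homo sapiens), read by Amplex Red, with a stated time of 15 min, tested at 100 uM (a higher number here means more inhibition at the concentration tested (going by the name of the read-out), a lower number less inhibition), compound 3 `CC(=O)c1cccc(OCc2ccc(F)cc2)c1` gives 49.6%, the highest of the three numbers measured so far. Compound 2 `CC(=O)c1ccc(OCc2ccccc2F)cc1` gives 47.1%, which sits within the scatter of compound 3, while compound 1 `CC(=O)c1ccc(OCc2ccccc2[N+](=O)[O-])cc1` gives 34%, beyond the scatter below it. Within the data shown here, the one measured step, a number 13.1 percentage points higher from compound 1 to compound 2 (beyond the scatter), came from a fluoro in place of nitro on an aromatic carbon. Compound 4 `CC(=O)c1cccc(OCc2ccc(C)cc2)c1` differs from compound 3 in one place: methyl in place of fluoro on an aromatic carbon. Among the measured compounds shown here, no measured step swaps methyl for fluoro, so that step is no direct guide, and the expectation is a change of a number 1.6 percentage points lower from compound 3 to compound 4 (within the scatter), within the scatter. Compound 4 is therefore estimated at 48%, with a range from 34% to 62%.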

Compound 4, a percentage reported as inhibition, at one concentration (the size of the read-out at that concentration, not a potency): 23%
The estimate for compound 4 lay 25 percentage points above the measured number, and the stated range ends above it.
By their numbers in this assay, from the lowest: compound 4; then compound 1; then compounds 2 and 3 (each within the scatter of the next).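

Methyl in place of fluoro, on an aromatic carbon para to a large group, gives a number 26.6 percentage points lower from compound 3 to compound 4 (beyond the scatter) in this assay. This position therefore responds to the swap, even though the two groups match in heavy-atom count and in hydrogen-bond donors and acceptors. Nothing available explains the difference. Open, going by these compounds, is how other groups at this position, such as chloro, methoxy or an amine, would compare with fluoro and methyl. Also open, on these data alone, is whether the same swap would give a similar step on another of these cores.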